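Notes on the step from compound 3 to compound 4

The compounds below may be only part of what the source reports. "The series", "measured", "known", "first", "only" and "open" are said of these compounds alone.

Measured compounds:
compound 1 `Cc1ccc(C(=O)Nc2cccc(CN3CCN(C)CC3)c2)cc1-c1ccc2cn[nH]c2c1` — 75.9 nM
compound 2 `Cc1ccc(C(=O)Nc2cc(CN3CCN(C)CC3)cc(C(F)(F)F)c2)cc1-c1ccc2cn[nH]c2c1` — 4.7 nM
compound 3 `CCCn1cc(-c2n[nH]c3cc(-c4cc(C(=O)Nc5cccc(C(F)(F)F)c5)ccc4C)ccc23)cn1` — 3.2 nM

In an assay on isolated protein for inhibition of Discoidin domain-containing receptor 2 (Homo sapiens), read by ELISA, with a stated time of 60 min (a higher number here means a weaker inhibitor, a lower number a stronger inhibitor), compound 3 gives 3.2 nM, the lowest of the three numbers, though compound 2 at 4.7 nM sits within the scatter of it; compound 1 at 75.9 nM lies beyond. Among the compounds with values here, the single one-place step measured, a 16-fold lower number from compound 1 to compound 2 (1.21 log units; beyond the scatter), concerns trifluoromethyl in place of hydrogen on an aromatic carbon and does not touch the part changed here. Compound 4 `Cc1ccc(C(=O)Nc2cccc(C(F)(F)F)c2)cc1-c1ccc2c(-c3cnn(CC(=O)N(C)C)c3)n[nH]c2c1` differs from compound 3 by dimethylcarbamoyl in place of ethyl on a saturated chain carbon bound to an aromatic nitrogen. Within the data shown here, no measured step bears on this change, so no shift beyond the scatter is expected in this assay. Compound 4 is expected to give about 4 nM (range 1.5 nM to 12 nM), an estimated step of a 1.3-fold higher number from compound 3 to compound 4 (0.10 log units; within the scatter).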

Compound 4, half-maximal inhibitory concentration: 2.7 nM
Beside the measured number, compound 4's estimate is 1.5-fold (0.17 log units) above it; the range from low to high includes it.
By their numbers in this assay, from the lowest: compounds 4, 3 and 2 (each within the scatter of the next); then compound 1.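

In this assay, dimethylcarbamoyl in place of ethyl on a saturated chain carbon bound to an aromatic nitrogen gives a 1.2-fold lower number from compound 3 to compound 4 (0.07 log units; within the scatter). This position therefore accepts a group of 5 heavy atoms with 1 hydrogen-bond acceptor in place of one of 2 heavy atoms with none, with no shift beyond the scatter. Nothing available accounts for this result.

On these data alone, how a primary amine or a carboxylic acid in place of dimethylcarbamoyl on this carbon would read remains open. As far as these compounds go, a longer chain bound to the aromatic nitrogen is equally open.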